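The compounds below may be only part of what the source reports. "The series", "measured", "known", "first", "only" and "open" are said of these compounds alone.

Three compounds have been measured in a functional assay on A549 cells (Homo sapiens) for antiproliferative activity, read by sulforhodamine B assay, with a stated time of 72 h; on this read-out higher numbers stand for weaker inhibition and lower numbers for stronger inhibition:

compound 1 `COc1ncc(-c2ccc3ncnc(Nc4ccc(OCCO)cc4)c3c2)cc1NS(C)(=O)=O` gives 5200 nM
compound 2 `COC(=O)Cn1cc(Nc2ncnc3ccc(-c4cnc(OC)c(NS(=O)(=O)c5ccc(F)cc5F)c4)cc23)cn1` gives 4280 nM
compound 3 `CCCCS(=O)(=O)Nc1cc(-c2ccc3ncnc(Nc4ccc(OCCO)nc4)c3c2)cnc1OC` gives 13300 nM

Compound 2 has the lowest of the three numbers. Its nearest neighbour is compound 1, whose number is only slightly higher and lies within the scatter, so the two cannot be set in order; compound 3 sits further away, with a gap beyond the scatter.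

Compound 4 `COc1cc(Nc2ncnc3ccc(-c4cnc(OC)c(NS(=O)(=O)c5ccc(F)cc5F)c4)cc23)ccc1OCCO` has not yet been measured. It differs from compound 2 in one place: 4-(2-hydroxyethoxy)-3-methoxyphenyl in place of 1-((methoxycarbonyl)methyl)-1H-pyrazol-4-yl on a nitrogen on an aromatic ring. Compound 1 carries a related hydroxyethoxy-bearing aryl group on the same nitrogen and its number sits close to that of compound 2, so no step beyond the scatter is expected, the estimated step being a 1.1-fold lower number from compound 2 to compound 4 (0.03 log units; within the scatter). Compound 4 is therefore expected to give about 4000 nM, within 1500 nM to 11000 nM.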

Compound 4, half-maximal inhibitory concentration: 3760 nM
Compound 4: middle estimate off by 1.1-fold (0.03 log units), on the high side, and the stated range covers the measured number.
By their numbers in this assay, from the lowest: compounds 4, 2 and 1 (each within the scatter of the next); then compound 3.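

In this assay, among the compounds shown here, 4-(2-hydroxyethoxy)-3-methoxyphenyl in place of 1-((methoxycarbonyl)methyl)-1H-pyrazol-4-yl on a nitrogen on an aromatic ring gives a 1.1-fold lower number from compound 2 to compound 4 (0.06 log units; within the scatter) as the first step that can be read in one place. For this pair, a six-membered aromatic ring of carbon only and a five-membered aromatic ring with 2 hetero atoms therefore cannot be told apart at this position. No measured evidence here accounts for this result.

On these data alone, whether an amine or a carboxylic acid at the end of the chain on this group would move the number beyond the scatter remains open. As far as these compounds go, the effect of the hydroxyethoxy and methoxy groups taken singly also remains open.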